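This account rests on a few compounds, and the source may have more. Where it says the series, first, only, none or still open, it means among the compounds named here.

Of the compounds shown here, two carrying the same core have been measured so far. Compound 1, `CC(C)(C)OC(=O)NCC(CCCCNC(=O)CCn1cccc(O)c1=O)NC(=O)OC(C)(C)C`, gives 94.7% in a physicochemical assay, read by spectrophotometry, with a stated time of 10 min, tested at 2 mM, in the presence of a further agent that is not named here; on this read-out higher numbers stand for a stronger effect at the one concentration tested and lower numbers for a weaker effect. Compound 2, `NCC(N)CC(=O)N1CCN(C(=O)CCn2cccc(O)c2=O)CC1`, gives 79% in this assay. Of the two numbers, compound 2 stands lowest; its nearest neighbour is compound 1, whose number lies higher by a margin that is beyond the usual scatter.

The next step leads from compound 2 to compound 3, `NCC(N)CCC(=O)N1CCN(C(=O)CCn2cccc(O)c2=O)CC1`. The change, counted from the two structures, is 2,3-diaminopropyl in place of 1,2-diaminoethyl on a saturated chain carbon bound to a carbonyl carbon. Both compounds keep the same core and the same piperazine-linked tail, so the change lies only in the length of that diamine-bearing chain.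

Among the measured compounds shown here, no measured pair shows what such a lengthening does here, so the expectation is a step of about a number 1 percentage points higher from compound 2 to compound 3 (within the scatter), not beyond the scatter. On that basis compound 3 is expected to give about 80% in this assay, somewhere between 65% and 92%.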

Compound 3, a percentage reported as activity, at one concentration (the size of the read-out at that concentration, not a potency): 76.5%
Compound 3: the middle estimate sits 3.5 percentage points above what was measured, and the stated range covers the measured number.
By their numbers in this assay, from the lowest: compounds 3 and 2 (each within the scatter of the next); then compound 1.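

Adding one carbon to the chain at this position, on a saturated chain carbon bound to a carbonyl carbon, gives a step in this assay of a number 2.5 percentage points lower from compound 2 to compound 3 (within the scatter) when 2,3-diaminopropyl takes the place of 1,2-diaminoethyl. The earlier compounds shown here offered no pair that differed in one place, so this is the only direct view of the change, and it shows that this lengthening does not move the read-out beyond the usual scatter. Nothing measured here explains this outcome.

From the compounds shown here alone, a single lengthening cannot show a trend with chain size, so whether a longer chain would also leave the read-out within the scatter stays open. The effect of replacing one of the two amines with a carboxylic acid at this position is also unknown.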